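The source may hold more compounds than are shown below. What is called first, only, known or untested is meant among the compounds shown, and "the series" means these compounds.

Working notes on the cytotoxicity series.

Compound 3 `CO/N=C(\C)CCN1CCN(c2nc(=O)c3cc(C(F)(F)F)cc([N+](=O)[O-])c3s2)CC1` gives in an ADME assay on Vero cells (Chlorocebus sabaeus) for cytotoxicity (a lower number here means that less compound is tolerated, a higher number that more compound is tolerated), only a limit, > 64 ug/mL. Compound 1 `CCO/N=C(\C)CN1CCN(c2nc(=O)c3cc(C(F)(F)F)cc([N+](=O)[O-])c3s2)CC1` sits at a limit too, > 64 ug/mL in this assay. Compound 2 `C/C(CN1CCN(c2nc(=O)c3cc(C(F)(F)F)cc([N+](=O)[O-])c3s2)CC1)=N\OCc1ccccc1` likewise returns a limit, > 64 ug/mL in this assay. Every value shown in this assay is therefore a limit: the limit of > 64 ug/mL in this assay, at which 3 of the 3 values shown sit.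

Compound 4 `CCO/N=C(\C)CCN1CCN(c2nc(=O)c3cc(C(F)(F)F)cc([N+](=O)[O-])c3s2)CC1` differs from compound 3 by methyl in place of hydrogen on a saturated chain carbon bound to an oxygen on an unsaturated carbon. The closest measured comparison is a step that the two limits leave unreadable from compound 1 to compound 2, which sits at the same place of the chain and cannot be read because both ends are limits. The two other steps, a step that the two limits leave unreadable from compound 1 to compound 3 and a step that the two limits leave unreadable from compound 2 to compound 3, are equally unreadable for the same reason, and they concern the longer group on the chain carbon bound to the amine nitrogen in the ring rather than the site changed here. Going by the values given here, no measured step in this assay shows any movement away from the limit, so nothing points to a readable change for compound 4.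

The expectation for compound 4 is therefore that it again reaches the limit in this assay, estimated at 70 ug/mL, with a range of 40 ug/mL to 120 ug/mL. The step from compound 3 to compound 4 is accordingly estimated as a step that the limit leaves unreadable from compound 3 to compound 4, that is, none beyond the scatter.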

Compound 4, half-maximal cytotoxic concentration: > 64 ug/mL
Compound 4 gave a limit, no number; the forecaster's own chance of this, stated with the estimate: 85%; the middle value does not contradict the limit.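

Compound 4 also returns only a limit, so none of its steps to compound 1, compound 2 or compound 3 can be read: the limit of > 64 ug/mL in this assay, at which 4 of the 4 values shown sit.

The compounds shown leave open where any of them truly lies in this assay, and whether methyl in place of hydrogen, or any other change among them, moves the read-out at all.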